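This account rests on a few compounds, and the source may have more. Where it says the series, first, only, none or still open, it means among the compounds named here.

Measured so far in a functional assay, read by spectrophotometry, with a stated time of 2 h, tested at 3 mg/mL; on this read-out lower numbers stand for a weaker effect and higher numbers for a stronger effect at the one concentration tested:
- compound 1, `CC(C)[C@@H]1CC[C@@H](C)C[C@@]12N(C)C(=O)[C@@H]1[C@H]3C(=O)NC(=O)[C@H]3ON12`: 47.3%
- compound 2, `CC(C)[C@@H]1CC[C@@H](C)C[C@@]12N(C)C(=O)[C@@H]1[C@H]3C(=O)N(C)C(=O)[C@H]3ON12`: 67.5%
- compound 3, `CC(C)[C@@H]1CC[C@@H](C)C[C@@]12N(C)C(=O)[C@@H]1[C@H]3C(=O)N(c4ccccc4)C(=O)[C@H]3ON12`: 58.9%

All three share one core and differ only in the group on an amide-type nitrogen in a ring. Compound 3 stands second highest of the three numbers. Its nearest neighbour is compound 2, which is a number 8.6 percentage points lower from compound 2 to compound 3 (within the scatter), a gap within the scatter, so the two cannot be ordered. Its furthest neighbour is compound 1, which is a number 11.6 percentage points higher from compound 1 to compound 3 (beyond the scatter), a step beyond the scatter, as is a number 20.2 percentage points higher from compound 1 to compound 2 (beyond the scatter).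

Compound 4, `CC(C)[C@@H]1CC[C@@H](C)C[C@@]12N(C)C(=O)[C@@H]1[C@H]3C(=O)N(c4ccc(Cl)cc4)C(=O)[C@H]3ON12`, is not yet measured. It differs from compound 3 by chloro in place of hydrogen on an aromatic carbon. Among the measured compounds shown here, no measured step alters the phenyl itself; the closest step, phenyl in place of methyl, is the one from compound 2 to compound 3 and lies within the scatter. On that basis a step within the scatter is expected for compound 4, with no direction favoured, giving an expected a number 1.1 percentage points higher from compound 3 to compound 4 (within the scatter).

Compound 4 is therefore estimated at 60% in this assay, with a range from 45% to 75%.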

Compound 4, a percentage reported as activity, at one concentration (the size of the read-out at that concentration, not a potency): 73.3%
Compound 4: middle estimate off by 13.3 percentage points, on the low side, and the stated range covers the measured number.
By their numbers in this assay, from the lowest: compound 1; then compounds 3, 2 and 4 (each within the scatter of the next, the first and the last beyond it).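

In this assay, the phenyl ring itself proves to be a place where a change can register: chloro in place of hydrogen on an aromatic carbon, para to a large group, gives a number 14.4 percentage points higher from compound 3 to compound 4 (beyond the scatter) and so moves the number by more than the usual scatter. Against the smaller groups on the same nitrogen, 4-chlorophenyl gives a number 26 percentage points higher from compound 1 to compound 4 (beyond the scatter) from the unsubstituted nitrogen, whereas a number 5.8 percentage points higher from compound 2 to compound 4 (within the scatter) means that the methyl and 4-chlorophenyl compounds cannot be ordered. Nothing measured here explains the chloro step.

On these data alone, whether a methoxy group, an amine or a carboxylic acid at this same ring carbon would behave like chloro remains open. Each number shows only a stronger or weaker effect at the one concentration tested.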